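Aryl swap on the shared core of compound 1: pre-measurement notes

The source may hold more compounds than are shown below. What is called first, only, known or untested is meant among the compounds shown, and "the series" means these compounds.

Measured compounds:
compound 1 `CCOC(=O)c1cnn(-c2nc(-c3cccc(OC)c3OC)c(C#N)c(=O)n2C)c1N` — 54 ug/mL
compound 2 `Cn1c(NN)nc(-c2ccccc2O)c(C#N)c1=O` — 38 ug/mL

Both values come from a functional assay, with a stated time of 20 min; a higher number here means a weaker inhibitor, a lower number a stronger inhibitor. On the two numbers shown, compound 1 carries the higher figure, but compound 2 lies within the usual scatter of it, so no order between the two is established and neither can be called the weaker or the stronger of the pair. Going by the values given here, no pair of measured compounds differs in a single place, so no single-change step is available from the data themselves.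

Compound 3 `CCOC(=O)c1cnn(-c2nc(-c3cccs3)c(C#N)c(=O)n2C)c1N` is the next candidate. It differs from compound 1 in one place: thiophen-2-yl in place of 2,3-dimethoxyphenyl on an aromatic carbon. The rest of compound 1 is kept unchanged.

Among the compounds with values here, with no comparable step among the measured compounds, the expectation for this change rests on the unchanged remainder of compound 1 alone. The step from compound 1 to compound 3 in this assay is expected to be a 1.1-fold higher number from compound 1 to compound 3 (0.05 log units; within the scatter), that is, none clearly beyond the scatter. Compound 3 is therefore estimated at 60 ug/mL, with a range from 25 ug/mL to 150 ug/mL.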

Compound 3, half-maximal inhibitory concentration: 79 ug/mL
For compound 3 the middle estimate is 1.3-fold (0.12 log units) below the measured one, within the range that was stated.
By their numbers in this assay, from the lowest: compounds 2, 1 and 3 (each within the scatter of the next, the first and the last beyond it).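

In this assay, going by these compounds alone, the one single-change step available reads a 1.5-fold higher number from compound 1 to compound 3 (0.17 log units; within the scatter), which lies within the scatter, so thiophen-2-yl and 2,3-dimethoxyphenyl are not told apart at this aromatic carbon ortho to a cyano group. Within the data shown here, the earlier compounds offered no such reading: this is the first sign that the position can carry a five-membered aromatic ring with one hetero atom in place of the six-membered carbon ring of compound 1 without a step beyond the scatter. Nothing at hand explains the step or links it to a measured property of either group.

Still open, going by these compounds, is whether any group at this aromatic carbon moves the number beyond the scatter, and whether an aromatic ring is needed there at all: plain phenyl, a pyridyl ring, a methyl group or an amine would each bear on that question. Also open, on these data alone, is how the rest of the molecule contributes, for instance a carboxylic acid in place of the ethyl ester on the shared core.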